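The compounds below may be only part of what the source reports. "The series", "measured", "known", "first", "only" and "open" are said of these compounds alone.

In an assay on HEK293 cells for inhibition of Voltage-dependent T-type calcium channel subunit alpha-1G (Homo sapiens), read by fluorescence, tested at 10 uM (on this read-out higher numbers stand for more inhibition at the one concentration tested (going by the name of the read-out) and lower numbers for less inhibition), three compounds sharing one core and differing only in the aromatic group on an amine nitrogen in a ring have been measured. Compound 1 `CCCc1nc(-c2ccccc2)c(CNCCN2CCN(c3ccccc3OC)CC2)o1` gives 39.7%, compound 2 `CCCc1nc(-c2ccccc2)c(CNCCN2CCN(c3ccc(F)cc3)CC2)o1` gives 54.1%, and compound 3 `CCCc1nc(-c2ccccc2)c(CNCCN2CCN(c3cccc(OC)c3)CC2)o1` gives 40.2%. Compound 3 thus stands second highest of the three: its nearest neighbour is compound 1, with a number 0.5 percentage points higher from compound 1 to compound 3 (within the scatter), while the gap to compound 2, a number 13.9 percentage points lower from compound 2 to compound 3 (beyond the scatter), lies beyond the scatter. Compound 4 `CCCc1nc(-c2ccccc2)c(CNCCN2CCN(c3cccc(C)c3C)CC2)o1` is not yet measured and differs from compound 3 in one place: 2,3-dimethylphenyl in place of 3-methoxyphenyl on an amine nitrogen in a ring. The earlier steps shown here all exchange this same aromatic group, namely a number 14.4 percentage points higher from compound 1 to compound 2 (beyond the scatter), a number 0.5 percentage points higher from compound 1 to compound 3 (within the scatter) and a number 13.9 percentage points lower from compound 2 to compound 3 (beyond the scatter), and they were modest at most. Going by these compounds, none of them brings in a 2,3-dimethylphenyl, so the direction stays open; the two methoxy variants sit together and the fluoro variant sits modestly higher. For compound 4 the expected step is a number 6.8 percentage points higher from compound 3 to compound 4 (within the scatter), a small rise or nothing beyond the scatter. Compound 4 is therefore estimated at 47% in this assay, between 30% and 65%.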

Compound 4, a percentage reported as inhibition, at one concentration (the size of the read-out at that concentration, not a potency): 66.7%
Estimate against measurement, compound 4: 19.7 percentage points below; measured number above the stated range.
By their numbers in this assay, from the lowest: compounds 1 and 3 (each within the scatter of the next); then compound 2; then compound 4.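

Swapping the 3-methoxyphenyl for the 2,3-dimethylphenyl keeps the heavy-atom count but removes the oxygen and the hydrogen-bond acceptor, and it gives a number 26.5 percentage points higher from compound 3 to compound 4 (beyond the scatter) on the amine nitrogen in the ring. Compound 4 also stands clear of the other two compounds, with a number 12.6 percentage points higher from compound 2 to compound 4 (beyond the scatter) and a number 27 percentage points higher from compound 1 to compound 4 (beyond the scatter), so the aromatic group at this position can move the number further than the fluoro and methoxy exchanges alone suggested. No measurement here explains the rise.

Going by these compounds, it remains open whether both methyl groups matter, since a 2-methylphenyl or a 3-methylphenyl alone would be needed to separate them. A single concentration also leaves the potency of compound 4 unknown, and a chlorophenyl or a pyridine ring at this position would test how far the trend extends.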